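Compounds 1 to 4: aryl swap on the nine-membered ring

The source may hold more compounds than are shown below. What is called first, only, known or untested is meant among the compounds shown, and "the series" means these compounds.

Measured in a functional assay on A549 cells (Homo sapiens) for antiproliferative activity, read by MTT assay, with a stated time of 72 h; a higher number here means a weaker inhibitor, a lower number a stronger inhibitor:
- compound 1 `C#Cc1cccc(Nc2ncnc3cc(OC)c(OCCCN4CCNCCNCCNCC4)cc23)c1`: 28600 nM
- compound 2 `COc1cc2ncnc(Nc3ccc(Br)cc3F)c2cc1OCCCN1CCNCCNCCNCC1`: 15200 nM
- compound 3 `C#Cc1cccc(Nc2ncnc3cc(OC)c(OCCCN4CCNCCNCC4)cc23)c1`: > 50000 nM

Compound 3 sits at the limit of > 50000 nM in this assay, at which 1 of the 3 values shown sits. That entry is a limit and not a number, so any step from it is poorly defined.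

Compound 4 `COc1cc2ncnc(Nc3ccc(F)c(Br)c3)c2cc1OCCCN1CCNCCNCC1` carries 3-bromo-4-fluorophenyl in place of 3-ethynylphenyl on a nitrogen on an aromatic ring.

The closest measured change replaces the same 3-ethynylphenyl on the larger ring, though with a different halogenated phenyl: a 1.9-fold lower number from compound 1 to compound 2 (0.27 log units; within the scatter). The ring change itself is an at least 1.7-fold higher number from compound 1 to compound 3 (0.24 log units; that floor lies within the scatter), and it shows only a floor. Neither step points to a real shift in this assay from an exchange of this aryl group, so compound 4 is expected to stay close to compound 3, quite possibly at the same limit.

The estimated change is an at least 1.1-fold lower number from compound 3 to compound 4 (0.04 log units; that floor lies within the scatter), which is expected to lie within the scatter.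

For compound 4 the estimate is 45000 nM, with an expected range of 18000 nM to 100000 nM.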

Compound 4, half-maximal inhibitory concentration: 34300 nM
Compound 4: the middle estimate sits 1.3-fold (0.12 log units) above what was measured; low and high end bracket the measured number.
By their numbers in this assay, from the lowest: compounds 2, 1 and 4 (each within the scatter of the next, the first and the last beyond it). At a limit, above all of these: compound 3.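

With the nine-membered ring, compound 4, carrying 3-bromo-4-fluorophenyl, gives the only number on this ring among the compounds shown in this assay: 34300 nM. The entry for compound 3 is a limit, not a number: the limit of > 50000 nM in this assay, at which 1 of the 4 values shown sits. The exchange of 3-ethynylphenyl for 3-bromo-4-fluorophenyl on this ring can be read only as a floor, an at least 1.4-fold lower number from compound 3 to compound 4 (0.16 log units; that floor lies within the scatter), so a real shift is neither shown nor excluded.

From the compounds shown here alone, the true size of this step stays open, as does whether any aryl group at this nitrogen would move the number beyond the scatter on the nine-membered ring. Also open, going by these compounds, is how an acetyl group on the ring nitrogens, or a shorter chain between the oxygen and the ring, would read in this assay.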